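The source may hold more compounds than are shown below. What is called first, only, known or untested is meant among the compounds shown, and "the series" means these compounds.

Compound 1 `Cc1cc(-c2nc3cccc(F)c3s2)ccc1N`: 7400 nM
Compound 2 `Cc1cc(-c2nc3c(F)cccc3s2)ccc1N`: 20900 nM
Compound 3 `Cc1cc(-c2nc3ccccc3s2)ccc1N`: 1100 nM

The three measured compounds share one core and differ only in a fluoro on one of its rings. In a functional assay on OVCAR-4 cells (Homo sapiens) for inhibition (a lower number here means a stronger inhibitor of growth, a higher number a weaker inhibitor of growth), compound 3, which carries no fluoro, gives the lowest number of the three. The step of a 6.7-fold lower number from compound 1 to compound 3 (0.83 log units; beyond the scatter) and the step of a 19-fold lower number from compound 2 to compound 3 (1.28 log units; beyond the scatter) both lie beyond the scatter, so compound 3 stands clearly apart from the other two, with compound 1 nearer to it and compound 2 furthest.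

Compound 4 `Nc1ccc(-c2nc3ccccc3s2)cc1F` has not yet been measured in this assay. It differs from compound 3 by fluoro in place of methyl on an aromatic carbon. Both measured steps concern hydrogen in place of fluoro on the other ring of the core, not the ring that carries the amino group, and neither involves a methyl; they therefore bear on this change only indirectly. What they do show is that each fluoro added to the core of compound 3 raised the number well beyond the scatter. A fluoro entering in place of methyl is expected to raise the number too, though less sharply. Compound 4 is therefore expected to give about 2500 nM in this assay, within 800 nM to 8000 nM. This estimate corresponds to an expected step of a 2.3-fold higher number from compound 3 to compound 4 (0.36 log units; beyond the scatter).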

Compound 4, concentration for 50% growth inhibition: 18600 nM
Compound 4: middle estimate off by 7.4-fold (0.87 log units), on the low side; measured number above the stated range.
By their numbers in this assay, from the lowest: compound 3; then compound 1; then compounds 4 and 2 (each within the scatter of the next).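

Going by these compounds alone, exchanging methyl for fluoro on the aromatic carbon ortho to an amino group gives a 17-fold higher number from compound 3 to compound 4 (1.23 log units; beyond the scatter) in this assay, so this position is sensitive to which group it carries, something the earlier compounds could not show because they all keep the methyl. The earlier steps shown here concern only fluoro and hydrogen elsewhere on the core, whereas this one shows that the number also moves strongly when the methyl itself leaves. Nothing at hand accounts for the size of this step or ties it to any measured property of either group.

The compounds shown do not separate the loss of the methyl from the arrival of the fluoro, and it remains open how hydrogen, chloro, ethyl or methoxy would fare on this same carbon. Going by these compounds, it also remains open whether the same exchange would give a step of similar size with a fluoro already on the other ring, as in compound 1 or compound 2.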